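Cyano Removed from the Dimethylphenyl Ring: Expected Cytotoxicity

The source may hold more compounds than are shown below. What is called first, only, known or untested is meant among the compounds shown, and "the series" means these compounds.

Of the compounds shown here, two with the same core have been measured. Compound 1, `COc1cc(C#N)cc(OC)c1Oc1nc(Nc2ccc(C#N)cc2)nc2ccccc12`, gives 194000 nM in an ADME assay on MT4 cells (Homo sapiens) for cytotoxicity, read by MTT assay, with a stated time of 4 days; a lower number here means that less compound is tolerated, a higher number that more compound is tolerated. Compound 2, `Cc1cc(C#N)cc(C)c1Oc1nc(Nc2ccc(C#N)cc2)nc2ccccc12`, gives 203000 nM in the same assay. Compound 2 carries the highest of the two numbers shown, but compound 1 lies within the scatter of it, so the two cannot be told apart.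

Compound 3, `Cc1cccc(C)c1Oc1nc(Nc2ccc(C#N)cc2)nc2ccccc12`, has not yet been measured in this assay. The change from compound 2 is hydrogen in place of cyano on an aromatic carbon, that is, 4-cyano-2,6-dimethylphenyl to 2,6-dimethylphenyl, on an aromatic carbon of a six-membered aromatic ring of carbon only.

Among the measured compounds shown here, no measured pair shows this change, so the expected effect rests on the two values alone, which sit close to each other despite different groups on that ring. The step from compound 2 to compound 3 is therefore expected to be small and to stay within the scatter, as a 1.1-fold lower number from compound 2 to compound 3 (0.05 log units; within the scatter). For compound 3 the estimated value is 180000 nM, with a range from 90000 nM to 360000 nM.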

Compound 3, half-maximal cytotoxic concentration: 35000 nM
Beside the measured number, compound 3's estimate is 5.1-fold (0.71 log units) above it, and the stated range ends above it.
By their numbers in this assay, from the lowest: compound 3; then compounds 1 and 2 (each within the scatter of the next).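

Cyano on this aromatic carbon, meta to two methyl groups and para to a large group, proves not to be a neutral feature in this assay. Hydrogen in its place gives a 5.8-fold lower number from compound 2 to compound 3 (0.76 log units; beyond the scatter) as a modest change, and it is the first step in this short series to be read beyond the scatter, with less of compound 3 tolerated than of compound 2. No measurement shown here explains this drop, so the result stands as an observation about this single pair.

The compounds shown leave open whether other groups at this position, such as an amine, a carboxylic acid or a longer chain, would stay close to compound 2 or fall towards compound 3. They also leave open whether hydrogen in place of cyano would lower the number to a similar degree on the ring of compound 1, which carries methoxy groups where compound 2 carries methyl groups, since this change has been read only once, on the 4-cyano-2,6-dimethylphenyl ring.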